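Swapping the chloropyridinyl amide for an indolyl amide

A few compounds are considered here, and "the series" means these few. Any claim that something is new, unique, unknown or untested is made for them only; others in the source may bear on it.

Compound 2 `CS(=O)(=O)N1C[C@H](C(=O)Nc2ccc(Cl)cn2)[C@@H](C(=O)Nc2ccc(-n3ccccc3=O)cc2F)C1` is the more lipophilic of the two measured analogues: in a physicochemical assay for lipophilicity, at pH 7.4 (on this read-out higher numbers stand for higher lipophilicity and lower numbers for lower lipophilicity), compound 2 gives 1.46, whereas compound 3 `O=C(Nc1ccc(Cl)cn1)[C@H]1CNC[C@@H]1C(=O)Nc1ccc(-n2ccccc2=O)cc1F` gives 0.63, a change of a number 0.83 log units lower from compound 2 to compound 3 (beyond the scatter). Compound 1 `O=C(Nc1ccc(Cl)cc1)[C@H]1CN(CC2CC2)C[C@@H]1C(=O)Nc1ccc(-n2ccccc2=O)cc1F` has no result in this assay, where compound 1 stands as "not determined" (no result reported). Compound 4 `CS(=O)(=O)N1C[C@H](C(=O)Nc2ccc3[nH]ccc3c2)[C@@H](C(=O)Nc2ccc(-n3ccccc3=O)cc2F)C1` differs from compound 2 by 1H-indol-5-yl in place of 5-chloropyridin-2-yl on an amide-type nitrogen. Going by the values given here, no measured step covers this exchange of aryl groups; the only known step concerns the ring nitrogen substituent and does not bear on it. The estimate for compound 4 therefore rests on compound 2 alone and is expected to be a modest rise, a number 0.34 log units higher from compound 2 to compound 4 (beyond the scatter). Compound 4 is thus expected to give about 1.8, within a range from 1.2 to 2.4.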

Compound 4, distribution coefficient: 1.07
The estimate for compound 4 lay 0.73 log units above the measured number, and the stated range ends above it.
By their numbers in this assay, from the lowest: compound 3; then compound 4; then compound 2.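

In this assay, the exchange of 5-chloropyridin-2-yl for 1H-indol-5-yl on the amide-type nitrogen gave a number 0.39 log units lower from compound 2 to compound 4 (beyond the scatter) and so showed that this position, untouched by the earlier measured step, also moves the read-out. The entering group has more heavy atoms and an added ring, yet the number fell. No measurement shown explains this direction. Going by these compounds, it remains open how a carboxylic acid or an amine on this aryl group would read, and whether the indolyl exchange gives a similar step with hydrogen on the ring nitrogen.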